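The source may hold more compounds than are shown below. What is called first, only, known or untested is meant among the compounds shown, and "the series" means these compounds.

Two compounds share one core and differ only in the group carried on one double-bonded ring carbon. Compound 1 `O=C1C=CC2(C=C1)OC(=O)C(c1cc3ccccc3s1)=C2c1ccccc1` carries a 1-benzothiophen-2-yl group there, and compound 2 `O=C1C=CC2(C=C1)OC(=O)C(c1ccc([N+](=O)[O-])cc1)=C2c1ccccc1` a 4-nitrophenyl group. In a functional assay on MDA-MB-231 cells (Homo sapiens) for antiproliferative activity, read by MTT assay, with a stated time of 48 h (a higher number here means a weaker inhibitor, a lower number a stronger inhibitor), compound 1 gives 32900 nM, and in this assay compound 2 gives 19000 nM. Among the compounds with values here, the step of a 1.7-fold lower number from compound 1 to compound 2 (0.24 log units; within the scatter) is the only measured step, and it lies within the scatter, so on these two numbers compound 2 cannot be set apart from compound 1. Compound 3 `O=C1C=CC2(C=C1)OC(=O)C(c1ccc(CO)cc1)=C2c1ccccc1` keeps the core of compound 2 and alters the group on that ring carbon: hydroxymethyl in place of nitro on an aromatic carbon. Within the data shown here, no measured step exchanges nitro for hydroxymethyl, and the one step that swaps the group on this same ring carbon, a 1.7-fold lower number from compound 1 to compound 2 (0.24 log units; within the scatter), left the readout within the scatter. Nothing measured therefore points to a step beyond the scatter, and compound 3 is expected to land close to compound 2, which gives 19000 nM. The expected step of a 1.1-fold higher number from compound 2 to compound 3 (0.02 log units; within the scatter) is small. The estimate for compound 3 in this assay is 20000 nM, with a range from 6000 nM to 65000 nM.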

Compound 3, half-maximal inhibitory concentration: 8850 nM
The estimate for compound 3 lay 2.3-fold (0.35 log units) above the measured number; low and high end bracket the measured number.
By their numbers in this assay, from the lowest: compound 3; then compounds 2 and 1 (each within the scatter of the next).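

Swapping nitro for hydroxymethyl on the aromatic ring, with the rest of the molecule unchanged, gives the first step in this assay that clearly exceeds the scatter: a 2.1-fold lower number from compound 2 to compound 3 (0.33 log units; beyond the scatter). The 4-(hydroxymethyl)phenyl group also stands apart from 1-benzothiophen-2-yl on the same double-bonded ring carbon, with a 3.7-fold lower number from compound 1 to compound 3 (0.57 log units; beyond the scatter), so this position can respond to the choice of group, although both steps are modest and compound 3 is the only one of the three clearly set apart. No supporting measurement is available to explain why the number falls.

Three compounds cannot show whether the hydrogen-bond donor that hydroxymethyl brings is what matters, or whether simply losing nitro is enough, and a methoxymethyl group, an aminomethyl group or a carboxylic acid in the same place on the ring would help separate these possibilities. On these data alone, the phenyl group shared by all three compounds also stays unchanged, so the effect of altering it remains unknown.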